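Iodo for Hydrogen on the Phenyl Ring of Compound 1

The source may report more compounds than this note shows. Statements on the series, on what has been measured and on what is new or still open speak of the compounds shown alone.

Going by the values given here, compound 1 `COc1ccccc1Oc1c(N)nc(-c2ccccc2)nc1Cl` gives 4610 nM in a functional assay on B16 cells (Mus musculus) for cytotoxicity, read by CCK-8 assay, with a stated time of 24 h (on this read-out higher numbers stand for weaker inhibition and lower numbers for stronger inhibition), the highest of the two numbers so far. Compound 2 `COc1ccccc1Oc1c(N)nc(-c2ccc(F)cc2)nc1Cl` gives 2990 nM in this assay, and the step of a 1.5-fold lower number from compound 1 to compound 2 (0.19 log units; within the scatter), fluoro in place of hydrogen on an aromatic carbon, stays within the scatter. Compound 3 `COc1ccccc1Oc1c(N)nc(-c2cccc(I)c2)nc1Cl` differs from compound 1 by iodo in place of hydrogen on an aromatic carbon. Among the compounds with values here, only the step to compound 2 bears on this, and it was small, so no shift beyond the scatter is expected in this assay. Compound 3 is therefore estimated at 3500 nM, within a range of 1500 nM to 8000 nM, which means an expected 1.3-fold lower number from compound 1 to compound 3 (0.12 log units; within the scatter).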

Compound 3, half-maximal inhibitory concentration: 27600 nM
For compound 3 the middle estimate is 7.9-fold (0.90 log units) below the measured one; measured number above the stated range.
By their numbers in this assay, from the lowest: compounds 2 and 1 (each within the scatter of the next); then compound 3.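

In this assay iodo on the phenyl ring gives a 6.0-fold higher number from compound 1 to compound 3 (0.78 log units; beyond the scatter) and so, unlike the fluoro step, moves the number beyond the scatter. The 3-iodophenyl group also gives a 9.2-fold higher number from compound 2 to compound 3 (0.97 log units; beyond the scatter) against 4-fluorophenyl, so the phenyl ring is not indifferent to what it carries, though this step changes both the halogen and its place. No measurement at hand accounts for the rise.

Going by these compounds, it remains open whether the rise follows from iodo itself or from its place on the ring. On these data alone, what an amine or a carboxylic acid would do there also remains open.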